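The source may hold more compounds than are shown below. What is called first, only, known or untested is meant among the compounds shown, and "the series" means these compounds.

Compound 1 `CN1C/C(=C\c2ccncc2)C(=O)/C(=C/c2ccccc2F)C1`: 14900 nM
Compound 2 `O=C1/C(=C/c2ccncc2)CN(S(=O)(=O)c2ccccc2)C/C1=C\c1ccccc1F`: 15900 nM
Compound 3 `O=C1/C(=C/c2ccncc2)CN(S(=O)(=O)c2ccc(F)cc2)C/C1=C\c1ccccc1F`: 15600 nM

In an ADME assay on L02 cells (Homo sapiens) for cytotoxicity, read by MTT assay, with a stated time of 24 h (on this read-out higher numbers stand for weaker inhibition and lower numbers for stronger inhibition), compound 3 gives 15600 nM, a number that cannot be told apart from those of compound 1 and compound 2, since all three lie within the usual scatter of repeated measurements.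

The next compound is compound 4 `O=C1/C(=C/c2ccncc2)CN(S(=O)(=O)c2ccc(Cl)cc2)C/C1=C\c1ccccc1F`. It differs from compound 3 by one swap: chloro in place of fluoro on an aromatic carbon. In words, this is chloro in place of fluoro on an aromatic carbon, para to a large group.

Among the measured compounds shown here, no chloro compound has been measured yet, so the evidence is indirect. Fluoro in place of hydrogen on an aromatic carbon gave a 1.0-fold lower number from compound 2 to compound 3 (0.01 log units; within the scatter). Larger swaps on the ring nitrogen gave a 1.1-fold higher number from compound 1 to compound 2 (0.03 log units; within the scatter) and a 1.0-fold higher number from compound 1 to compound 3 (0.02 log units; within the scatter). None of these steps moved this assay beyond the scatter, so a swap of one halogen for another is not expected to do so either.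

The expected change is a 1.0-fold lower number from compound 3 to compound 4 (0.02 log units; within the scatter), which stays within the scatter.

The estimate for compound 4 is 15000 nM, with an expected range of 9000 nM to 24000 nM.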

Compound 4, half-maximal inhibitory concentration: 15000 nM
Compound 4: the middle estimate sits on the measured number at the digits printed; the measured number falls inside the stated range.
By their numbers in this assay, from the lowest: compounds 1, 4, 3 and 2 (each within the scatter of the next).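

In this assay, the first chlorine at this position, on the ring of the sulfonyl group, gives a 1.0-fold lower number from compound 3 to compound 4 (0.02 log units; within the scatter) and so adds a direct halogen-for-halogen comparison to the earlier fluoro step, again without a detectable change. The other two comparisons agree: chloro in place of hydrogen gives a 1.1-fold lower number from compound 2 to compound 4 (0.03 log units; within the scatter) and the whole (4-chlorophenyl)sulfonyl group in place of methyl on the amine nitrogen in the ring gives a 1.0-fold higher number from compound 1 to compound 4 (0.00 log units; within the scatter) and thus all four compounds remain indistinguishable in this read-out. No accompanying measurement offers an explanation for this flat result.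

On these data alone, only hydrogen, fluoro and chloro appear at this position, so it remains open whether a methoxy group, an amine or a carboxylic acid there would shift the number beyond the scatter. Likewise, the compounds shown leave open whether a longer alkyl chain on the ring nitrogen would do so.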